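This account rests on a few compounds, and the source may have more. Where it says the series, first, only, none or still open, it means among the compounds named here.

In a functional assay on NCI-H520 cells (Homo sapiens) for cytotoxicity (on this read-out higher numbers stand for weaker inhibition of growth and lower numbers for stronger inhibition of growth), compound 3 `CSc1ccc(C2=C(c3ccc(O)cc3)C(=O)N3CCCC3C2)cc1` gives > 100000 nM, which is a limit of the assay and not a number. Two relatives share its core. Compound 1 `CSc1ccc(C2=C(c3ccc(F)c(F)c3)C(=O)N3CCCC3C2)cc1`, which carries halogen on that aryl ring, gives 200 nM, and compound 2 `CSc1ccc(C2=C(c3ccc(O)c(O)c3)C(=O)N3CCCC3C2)cc1`, which carries hydroxy groups, gives 60000 nM. The next analogue, compound 4 `CSc1ccc(C2=C(c3ccc(Br)cc3)C(=O)N3CCCC3C2)cc1`, differs from compound 3 as follows: bromo in place of hydroxy on an aromatic carbon. Two large measured steps bear on this change, a 300-fold higher number from compound 1 to compound 2 (2.48 log units; beyond the scatter) and an at least 500-fold higher number from compound 1 to compound 3 (2.69 log units; beyond the scatter), and both lead from halogen to hydroxy. Compound 4 reverses that kind of swap with a single bromo, so a large fall in the number is expected, an estimated at least 160-fold lower number from compound 3 to compound 4 (2.22 log units; beyond the scatter). For compound 4 the estimated value is 600 nM, with an expected range of 100 nM to 5000 nM.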

Compound 4, concentration for 50% growth inhibition: 7000 nM
Compound 4: the middle estimate sits 12-fold (1.07 log units) below what was measured; measured number above the stated range.
By their numbers in this assay, from the lowest: compound 1; then compound 4; then compound 2. At a limit, above all of these: compound 3.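

In this assay, a single bromo on this aryl ring brings back much of the growth inhibition seen without hydroxy groups (an at least 14-fold lower number from compound 3 to compound 4 (1.15 log units; beyond the scatter)), and 4-bromophenyl also improves on 3,4-dihydroxyphenyl (an 8.6-fold lower number from compound 2 to compound 4 (0.93 log units; beyond the scatter)). The first of these steps starts from a limit of the assay, not a number: the limit of > 100000 nM in this assay, at which 1 of the 4 values shown sits. Halogen alone does not settle the matter, since 3,4-difluorophenyl stays ahead (a 35-fold higher number from compound 1 to compound 4 (1.54 log units; beyond the scatter)). The compounds shown cannot separate the kind of halogen from the number of halogens, as a 4-fluorophenyl could. From the compounds shown here alone, whether a methoxy group or an amine here behaves like hydroxy or like bromo also stays open.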